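Replacing methoxycarbonyl with hydroxy in compound 2

The source may report more compounds than this note shows. Statements on the series, on what has been measured and on what is new or still open speak of the compounds shown alone.

Measured in an ADME assay on HT-29 cells (Homo sapiens) for cytotoxicity, read by MTT assay, with a stated time of 72 h (on this read-out lower numbers stand for stronger inhibition and higher numbers for weaker inhibition), so far:
Compound 1 `COc1ccc(C2=C(c3cc(OC)c(OC)c(OC)c3)CC(O)C2=O)cc1[N+](=O)[O-]` gives > 100 ug/mL as a limit
Compound 2 `COC(=O)c1cc(C2=C(c3cc(OC)c(OC)c(OC)c3)C(=O)CC2O[SiH2]C(C)(C)C)ccc1OC` gives > 100 ug/mL as a limit
Compound 3 `COc1ccc(C2=C(c3cc(OC)c(OC)c(OC)c3)C(=O)CC2OC(C)=O)cc1NC=O` gives < 1 ug/mL as a limit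

Compound 2 stands at the limit of > 100 ug/mL in this assay, at which 2 of the 3 values shown sit, and so has a limit, not a number. Compound 4 `COc1ccc(C2=C(c3cc(OC)c(OC)c(OC)c3)C(=O)CC2O[SiH2]C(C)(C)C)cc1O` differs from compound 2 by hydroxy in place of methoxycarbonyl on an aromatic carbon with hydroxy in place of methoxycarbonyl on an aromatic carbon. The expectation rests on compound 3 at < 1 ug/mL as a limit and it also lacks methoxycarbonyl. Compound 1 lacks it too and goes against this, at > 100 ug/mL as a limit. In this assay a large move towards stronger inhibition is expected, estimated as an at least 66-fold lower number from compound 2 to compound 4 (1.82 log units; beyond the scatter) in size. For compound 4 the estimate is 1.5 ug/mL with an expected range from 0.2 ug/mL to 30 ug/mL.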

Compound 4, half-maximal inhibitory concentration: 38 ug/mL
The estimate for compound 4 lay 25-fold (1.40 log units) below the measured number; the whole stated range lies below it.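

On this aromatic carbon, ortho to a methoxy group, hydroxy in place of methoxycarbonyl gives an at least 2.6-fold lower number from compound 2 to compound 4 (0.42 log units; beyond the scatter) in this assay. This position therefore affects the read-out, and compound 4 is the only compound shown with a number rather than a limit. The step gives only the smallest possible size of the change, as compound 2 stands at a limit: the limit of > 100 ug/mL in this assay, at which 2 of the 4 values shown sit.

The compounds shown leave open whether the change comes from hydroxy itself or from the loss of methoxycarbonyl, and how an amine or a carboxylic acid would read on this carbon. Going by these compounds alone, only this one pair differs in one place, so whether the step would hold on another core also remains open.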